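Swapping a chloro for trifluoromethyl on the anilide ring

The compounds below may be only part of what the source reports. "The series", "measured", "known", "first", "only" and "open" are said of these compounds alone.

Measured compounds:
compound 1 `CN(C)C(=O)c1cc2cnc(Nc3ccc(NC(=O)C4(C(=O)Nc5ccc(Cl)cc5)CC4)cc3)nc2n1C1CCCC1` gives 95% in a functional assay on T47D cells (Homo sapiens) for inhibition, read by CCK-8 assay, with a stated time of 72 h, tested at 10 uM; on this read-out lower numbers stand for less inhibition of growth and higher numbers for more inhibition of growth at the one concentration tested
compound 2 `CN(C)C(=O)c1cc2cnc(Nc3ccc(NC(=O)C4(C(=O)Nc5cccc(F)c5)CC4)cc3)nc2n1C1CCCC1` gives -0.4% in this assay
compound 3 `CN(C)C(=O)c1cc2cnc(Nc3ccc(NC(=O)C4(C(=O)Nc5cccc(Cl)c5)CC4)cc3)nc2n1C1CCCC1` gives 92.6% in this assay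

Compound 1 stands highest of the three numbers in this assay, though compound 3 sits within the scatter of it, and compound 2 lies far below both. Compound 4 `CN(C)C(=O)c1cc2cnc(Nc3ccc(NC(=O)C4(C(=O)Nc5ccc(C(F)(F)F)cc5)CC4)cc3)nc2n1C1CCCC1` has not yet been measured; it differs from compound 1 in one place: trifluoromethyl in place of chloro on an aromatic carbon. Among the compounds with values here, no measured step exchanges a chloro for a trifluoromethyl, so the estimate rests on neighbours. The step of a number 2.4 percentage points lower from compound 1 to compound 3 (within the scatter) shows that moving the chloro around the ring leaves the growth inhibition unchanged, while a number 93 percentage points higher from compound 2 to compound 3 (beyond the scatter) shows that a fluoro in place of the chloro removes it almost entirely. A larger halogen-type substituent at the same position is therefore expected to keep the inhibition high rather than collapse it, so compound 4 is expected to show a number 7 percentage points lower from compound 1 to compound 4 (within the scatter), a step within the scatter in either direction. The estimate for compound 4 is 88%, with a range from 40% to 100%.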

Compound 4, percent growth inhibition at one concentration: 94.9%
Compound 4: the middle estimate sits 6.9 percentage points below what was measured, within the range that was stated.
By their numbers in this assay, from the lowest: compound 2; then compounds 3, 4 and 1 (each within the scatter of the next).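

At this position on the anilide ring, trifluoromethyl matches chloro in this assay with a number 0.1 percentage points lower from compound 1 to compound 4 (within the scatter) and so shows that the high inhibition does not depend on chloro itself. The 4-(trifluoromethyl)phenyl group is also level with the 3-chlorophenyl group, with a number 2.3 percentage points higher from compound 3 to compound 4 (within the scatter) on this read-out, while a number 95.3 percentage points higher from compound 2 to compound 4 (beyond the scatter) leaves the 3-fluorophenyl group as the only one of the four with a low number. Nothing given here explains why the read-out holds with some of these groups and collapses with another.

As far as these compounds go, how a fluoro, a methoxy or a nitrile would behave at this same position remains open. With a single tested concentration, compounds 1, 3 and 4 could also still differ at lower concentrations.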